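Chlorophenyl position in a pyridine series: a second test

The source may report more compounds than this note shows. Statements on the series, on what has been measured and on what is new or still open speak of the compounds shown alone.

Three members of the series have been run in an assay on isolated protein for inhibition of DNA topoisomerase 1 (Homo sapiens), with a stated time of 30 min, tested at 100 uM; on this read-out higher numbers stand for a stronger effect at the one concentration tested and lower numbers for a weaker effect. Compound 1 `Oc1ccc(-c2cc(-c3cccs3)nc(-c3ccccc3Cl)c2)cc1` gives 2.2% in this assay. Among the compounds with values here, compound 2 `Oc1ccc(-c2cc(-c3ccc(Cl)cc3)nc(-c3cccs3)c2)cc1` gives 38.8% in this assay, and the step of a number 36.6 percentage points higher from compound 1 to compound 2 (beyond the scatter) is the one structural change that is covered twice here: 4-chlorophenyl in place of 2-chlorophenyl on an aromatic carbon. Compound 3 `Oc1cccc(-c2cc(-c3cccnc3)nc(-c3ccccc3Cl)c2)c1` gives 0% in this assay; against compound 1 this is within the scatter, against compound 2 it is beyond it. The difference between the core of compound 3 and the core of compound 1 is not broken down here.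

Compound 4 `Oc1cccc(-c2cc(-c3ccc(Cl)cc3)nc(-c3cccnc3)c2)c1` has not been run in this assay. It stands to compound 3 as compound 2 stands to compound 1: 4-chlorophenyl in place of 2-chlorophenyl on an aromatic carbon. This is the same kind of change, but not the same one, since the place is meta to a 3-hydroxyphenyl group and meta to a pyridin-3-yl group in compound 3, whereas in compound 1 it is meta to a 4-hydroxyphenyl group and meta to a thiophen-2-yl group. Within the data shown here, with only one earlier instance, the step from compound 3 to compound 4 is expected to point the same way but its size is uncertain, and it is estimated at a number 20 percentage points higher from compound 3 to compound 4 (beyond the scatter) because compound 3 starts from 0% and the single precedent is a number 36.6 percentage points higher from compound 1 to compound 2 (beyond the scatter). Compound 4 is therefore estimated at 20% in this assay, within 0% to 45%.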

Compound 4, a percentage reported as inhibition, at one concentration (the size of the read-out at that concentration, not a potency): 2.8%
Beside the measured number, compound 4's estimate is 17.2 percentage points above it; measured number inside the range.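

In this assay, 4-chlorophenyl in place of 2-chlorophenyl gives a number 2.8 percentage points higher from compound 3 to compound 4 (within the scatter), so on the core of compound 3 the two chlorophenyl isomers cannot be told apart at the one concentration tested. The change therefore does not carry over with its size intact, and the earlier large step cannot be treated as a fixed increment for this series: the same change on two cores in this assay, a number 36.6 percentage points higher (beyond the scatter) from compound 1 to compound 2 and a number 2.8 percentage points higher (within the scatter) from compound 3 to compound 4, 33.8 percentage points apart, beyond the scatter of two such steps This does not show which feature of the cores decides the outcome, since they differ in more than one place, with a 4-hydroxyphenyl and a thiophen-2-yl group on the core of compound 1 and a 3-hydroxyphenyl and a pyridin-3-yl group on the core of compound 3, and two pairs of compounds give no rule for other cores.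

The compounds shown leave open whether the hydroxyphenyl group or the other aryl group governs the response to the chlorophenyl change, a question that a pair carrying 3-hydroxyphenyl with thiophen-2-yl, or 4-hydroxyphenyl with pyridin-3-yl, could separate. They also leave open how the series behaves when an amine or a carboxylic acid replaces the hydroxyl group on the phenyl ring.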